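Replacing phenyl with (methylamino)methyl in compound 3

This account rests on a few compounds, and the source may have more. Where it says the series, first, only, none or still open, it means among the compounds named here.

In a functional assay on HCT-116 cells (Homo sapiens) for antiproliferative activity (on this read-out higher numbers stand for weaker inhibition and lower numbers for stronger inhibition), three compounds that share one core have been measured. Compound 1 `C=CCO/N=C/c1c(N)ncnc1Oc1ccc2[nH]c(C)cc2c1F` gives 40 nM in this read-out, compound 2 `Cc1cc2c(F)c(Oc3ncnc(N)c3/C=N/O)ccc2[nH]1` gives 1140 nM in the same read-out, and compound 3 `Cc1cc2c(F)c(Oc3ncnc(N)c3/C=N/OCc3ccccc3)ccc2[nH]1` gives 311 nM and so stands second highest of the three.

Going on to compound 4 `CNCCO/N=C/c1c(N)ncnc1Oc1ccc2[nH]c(C)cc2c1F` the change is (methylamino)methyl in place of phenyl on a saturated chain carbon bound to an oxygen in which (methylamino)methyl takes the place of phenyl on a saturated chain carbon bound to an oxygen, turning benzyl into 2-(methylamino)ethyl. Among the measured compounds shown here, no measured compound carries this chain, so the evidence is indirect. For the measured compounds named here, the closest precedent is a 7.8-fold higher number from compound 1 to compound 3 (0.89 log units; beyond the scatter) with phenyl in place of vinyl, which suggests that losing phenyl from this carbon need not cost activity. The steps of a 29-fold higher number from compound 1 to compound 2 (1.45 log units; beyond the scatter) and a 3.7-fold lower number from compound 2 to compound 3 (0.56 log units; beyond the scatter) show that the number moves beyond the scatter with the group on this oxygen, and hydrogen gives the highest number of the three. A modest move towards a lower number is therefore expected, though with little certainty. The estimated step is a 3.1-fold lower number from compound 3 to compound 4 (0.49 log units; beyond the scatter) on this reasoning. Compound 4 is estimated at 100 nM with an expected range from 25 nM to 400 nM in this read-out.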

Compound 4, half-maximal inhibitory concentration: 3010 nM
Compound 4: middle estimate off by 30-fold (1.48 log units), on the low side, and the stated range ends below it.
By their numbers in this assay, from the lowest: compound 1; then compound 3; then compound 2; then compound 4.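

In this assay, (methylamino)methyl in place of phenyl on a saturated chain carbon bound to an oxygen gives a 9.7-fold higher number from compound 3 to compound 4 (0.99 log units; beyond the scatter) and so runs opposite to the step from phenyl to vinyl: losing phenyl from this carbon does not by itself lower the number, and the group that enters sets the direction. Set against hydrogen on the oxygen, 2-(methylamino)ethyl gives a 2.6-fold higher number from compound 2 to compound 4 (0.42 log units; beyond the scatter) and set against allyl it gives a 75-fold higher number from compound 1 to compound 4 (1.88 log units; beyond the scatter) as the largest gap among the four compounds, so a group on this oxygen need not lower the number: allyl and benzyl do so relative to hydrogen, while 2-(methylamino)ethyl goes against that pattern. Nothing available here accounts for the size of these steps.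

The compounds shown leave open whether the higher number goes with the nitrogen of the chain, which a 2-methoxyethyl or a propyl chain on the same oxygen would help to settle. They also leave open whether a tertiary amine such as 2-(dimethylamino)ethyl, or a longer chain such as 3-(methylamino)propyl, would behave as 2-(methylamino)ethyl does.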